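Acetyl for Benzyl on the Ring Nitrogen

The source may hold more compounds than are shown below. What is called first, only, known or untested is meant among the compounds shown, and "the series" means these compounds.

In a functional assay on ECa-109 cells for inhibition, with ECa-109 cell line (Homo sapiens) as the target, read by MTT assay, with a stated time of 48 h (on this read-out lower numbers stand for stronger inhibition and higher numbers for weaker inhibition), compound 1 (`COc1ccc(-c2coc3cc(OCCCSC(=S)N4CCN(C)CC4)ccc3c2=O)cc1`) gives 24200 nM and compound 2 (`COc1ccc(-c2coc3cc(OCCCSC(=S)N4CCN(Cc5ccccc5)CC4)ccc3c2=O)cc1`) gives 25300 nM, so compound 2 stands level with compound 1, within the scatter. Compound 3 (`COc1ccc(-c2coc3cc(OCCCSC(=S)N4CCN(C(C)=O)CC4)ccc3c2=O)cc1`) carries acetyl in place of benzyl on an amine nitrogen in a ring. Within the data shown here, the only measured step at this place, a 1.0-fold higher number from compound 1 to compound 2 (0.02 log units; within the scatter), lies within the scatter, though no acetyl compound has been measured. In this assay no change beyond the scatter is expected, the estimated step being a 1.0-fold lower number from compound 2 to compound 3 (0.01 log units; within the scatter). For compound 3 the expected value is 25000 nM, with an estimated range of 11000 nM to 55000 nM.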

Compound 3, half-maximal inhibitory concentration: 24700 nM
The estimate for compound 3 lay 1.0-fold (0.01 log units) above the measured number; low and high end bracket the measured number.
By their numbers in this assay, from the lowest: compounds 1, 3 and 2 (each within the scatter of the next).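

In this assay, replacing benzyl with acetyl removes the aromatic ring and adds a hydrogen-bond acceptor, yet the result is a 1.0-fold lower number from compound 2 to compound 3 (0.01 log units; within the scatter), and replacing methyl with acetyl gives a 1.0-fold higher number from compound 1 to compound 3 (0.01 log units; within the scatter). Thus, an acyl group on this amine nitrogen in a ring stands level with both alkyl groups, which the methyl and benzyl pair alone could not show. No measured evidence bears on why these compounds stand level.

The compounds shown leave open whether a phenyl group placed directly on this nitrogen, or a carboxylic acid carried on a longer chain there, would move the number beyond the scatter. They also leave open whether any change elsewhere on the shared core would do so.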